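Carboxymethyl for carboxycyclopropyl on the biaryl acid core

This account rests on a few compounds, and the source may have more. Where it says the series, first, only, none or still open, it means among the compounds named here.

Measured compounds:
compound 1 `O=C1CN(Cc2ccc(-c3ccc(C4(C(=O)O)CC4)cc3)cc2)C(=O)N1c1ccccc1` gives 195 ug/mL
compound 2 `O=C(O)Cc1ccccc1-c1cccc(NC(=O)OCc2ccccc2)c1` gives 287 ug/mL
compound 3 `O=C(O)Cc1ccc(-c2cccc(NC(=O)OCc3ccccc3)c2)cc1` gives 198 ug/mL

In a physicochemical assay for solubility, in phosphate buffer, measured as kinetic solubility, with a stated time of 1 h, at pH 7.4 (on this read-out higher numbers stand for higher solubility and lower numbers for lower solubility), the three values sit close together. Compound 1 has compound 3 as its nearest neighbour and compound 2 as its furthest, and both of those gaps are within the scatter, so no order among the three can be read from the numbers.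

Compound 4 `O=C(O)Cc1ccc(-c2ccc(CN3CC(=O)N(c4ccccc4)C3=O)cc2)cc1` is the next point in the series. Compound 4 differs from compound 1 by carboxymethyl in place of 1-carboxycyclopropyl on an aromatic carbon; in words, carboxymethyl in place of 1-carboxycyclopropyl on an aromatic carbon. Going by the values given here, no measured pair shows this step, so the expectation rests on the spread already seen. Compound 4 is expected to stay within the scatter of compound 1, with the step from a 1.2-fold higher number from compound 1 to compound 4 (0.07 log units; within the scatter) taken as small. The estimate for compound 4 is 230 ug/mL, ranging from 110 ug/mL to 460 ug/mL.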

Compound 4, solubility: 175 ug/mL
Estimate against measurement, compound 4: 1.3-fold (0.12 log units) above, and the stated range covers the measured number.
By their numbers in this assay, from the lowest: compounds 4, 1, 3 and 2 (each within the scatter of the next).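

In this assay, going by these compounds alone, the first matched step at this position, on an aromatic carbon para to a large group, reads a 1.1-fold lower number from compound 1 to compound 4 (0.05 log units; within the scatter) and lies within the scatter. For this one pair, carboxymethyl in place of 1-carboxycyclopropyl, with the three-membered ring gone, leaves no readable change in the read-out. Nothing at hand bears on the reason for this result.

Open, from the compounds shown here alone, is whether an amine or a longer chain carrying the carboxylic acid at this position would stay within the scatter of compound 1. Also open, going by these compounds, is whether this step reads the same on other cores.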